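A few compounds are considered here, and "the series" means these few. Any claim that something is new, unique, unknown or untested is made for them only; others in the source may bear on it.

Compounds measured in an in vitro functional assay on cells for agonist activity at Bombesin receptor subtype-3 (Homo sapiens), read by luminescence and calcium flux; on this read-out lower numbers stand for an effect already at smaller amounts and higher numbers for an effect only at larger amounts of compound:
compound 1, `CCCCc1cnc(CCc2ccc(-c3ccccc3C(=O)O)cc2)[nH]1`: 2710 nM
compound 2, `CCCCc1cnc(C(CCC)Cc2ccc(-c3ccccc3C(=O)O)cc2)[nH]1`: 1180 nM
compound 3, `CCCCc1cnc(Cc2ccc(-c3ccccc3C(=O)O)cc2)[nH]1`: > 10000 nM

Compound 1 stands at the higher of the two numbers; compound 2 sits at the lower one, with a 2.3-fold lower number from compound 1 to compound 2 (0.36 log units; beyond the scatter) after propyl enters on the chain carbon that joins the two ring systems. For compound 3 this assay gives only a limit, (the limit of > 10000 nM in this assay, at which 1 of the 3 values shown sits), and no number.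

Compound 4, `O=C(O)c1ccccc1-c1ccc(CCc2ncc(Cc3ccc(F)cc3)[nH]2)cc1`, is not yet measured. Against compound 1 the change is 4-fluorophenyl in place of propyl on a saturated chain carbon bound to an aromatic carbon; cut one bond further out it reads butyl to 4-fluorobenzyl, so it sits on the chain that hangs from the shared core, not on the linker carbon altered from compound 1 to compound 2. That measured step therefore does not bear on it, and the limit of compound 3 concerns the linker length only. Within the data shown here, no measured step speaks to the exchange itself, so in this assay no step beyond the scatter is expected from compound 1 to compound 4: a 1.1-fold lower number from compound 1 to compound 4 (0.04 log units; within the scatter). Compound 4 is estimated at 2500 nM, within 700 nM to 9000 nM.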

Compound 4, half-maximal effective concentration: 1600 nM
For compound 4 the middle estimate is 1.6-fold (0.19 log units) above the measured one, within the range that was stated.
By their numbers in this assay, from the lowest: compounds 2, 4 and 1 (each within the scatter of the next, the first and the last beyond it). At a limit, above all of these: compound 3.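

In this assay, 4-fluorophenyl in place of propyl on a saturated chain carbon bound to an aromatic carbon gives a 1.7-fold lower number from compound 1 to compound 4 (0.23 log units; within the scatter). Among these compounds, the earlier compounds varied only the linker, so this is the first reading on the chain that hangs from the shared core: here butyl and 4-fluorobenzyl cannot be told apart, and this position tolerates an aromatic ring and more heavy atoms without a step beyond the scatter. Nothing on hand offers an explanation that bears on this exchange.

A single exchange does not separate the ring from the fluorine, and a plain benzyl or a longer alkyl chain at this position would speak to that. Also open, going by these compounds, is how 4-fluorobenzyl on this chain reads together with the propyl of compound 2 on the linker carbon.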